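The compounds below may be only part of what the source reports. "The series", "measured", "known", "first", "only" and "open" are said of these compounds alone.

Among the compounds with values here, in a functional assay on DU-145 cells (Homo sapiens) for inhibition, read by trypan blue exclusion, with a stated time of 96 h (on this read-out lower numbers stand for stronger inhibition of growth and higher numbers for weaker inhibition of growth), compound 2 `Cc1ccc(CS/C(=C/c2sccc2C)C(=O)c2ccc(Cl)cc2)cc1` gives 10000 nM, the lower of the two numbers so far, while compound 1 `Cc1ccc(CS/C(=C/c2ccc(O)c(O)c2O)C(=O)c2ccc(Cl)cc2)cc1` gives 50000 nM. Compound 3 `COc1ccccc1/C=C(/SCc1ccc(C)cc1)C(=O)c1ccc(Cl)cc1` differs from compound 2 at a single place: 2-methoxyphenyl in place of 3-methylthiophen-2-yl on a double-bonded chain carbon bound to a double-bonded chain carbon. This puts 2-methoxyphenyl in place of 3-methylthiophen-2-yl on a double-bonded chain carbon bound to a double-bonded chain carbon. Within the data shown here, only one measured step bears on this place: a 5.0-fold lower number from compound 1 to compound 2 (0.70 log units; beyond the scatter), a modest change beyond the scatter. Among the measured compounds shown here, that single step gives no firm direction for the new group, and no measured compound yet carries it. In this assay the expected outcome is therefore no step beyond the scatter, with a slight lean toward a higher number. The estimated step is a 1.5-fold higher number from compound 2 to compound 3 (0.18 log units; within the scatter). For compound 3 the expected value is 15000 nM, with an estimated range of 5000 nM to 50000 nM.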

Compound 3, concentration for 50% growth inhibition: 10000 nM
Compound 3: middle estimate off by 1.5-fold (0.18 log units), on the high side, and the stated range covers the measured number.
By their numbers in this assay, from the lowest: compounds 2 and 3 (each within the scatter of the next); then compound 1.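

In this assay, 2-methoxyphenyl in place of 3-methylthiophen-2-yl on a double-bonded chain carbon bound to a double-bonded chain carbon gives no change at the digits printed from compound 2 to compound 3 (within the scatter), so this position does not separate the five-membered aromatic ring from the six-membered carbon ring in this pair. The 2,3,4-trihydroxyphenyl group of compound 1 now stands apart from two different groups, with a 5.0-fold lower number from compound 1 to compound 3 (0.70 log units; beyond the scatter) alongside a 5.0-fold lower number from compound 1 to compound 2 (0.70 log units; beyond the scatter). No supporting data accompany these numbers to explain the pattern.

The compounds shown leave open how an amine or a carboxylic acid on the aromatic ring at this place would read, and whether any group here can go beyond compound 2 and compound 3. On these data alone, they also vary only this place, so the contribution of the rest of the shared core remains open.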